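The compounds below may be only part of what the source reports. "The series", "measured", "known", "first", "only" and "open" are said of these compounds alone.

Three compounds share a fused two-ring core and were measured in an assay on cells for displacement of a labelled ligand from adenosine receptor A1 (Homo sapiens), read by scintillation counting and radioligand binding, with a stated time of 60 min; a lower number here means a stronger inhibitor, a higher number a weaker inhibitor. Compound 1 `Clc1ccc(-c2nc(N3CCCCC3)c3nc[nH]c3n2)cc1` gives 126 nM. Compound 2 `CN1CCN(c2nc(-c3cc(Cl)ccc3Cl)nc3[nH]cnc23)CC1` gives 2510 nM. Compound 3 `CN1CCN(c2nc(-c3ccccc3O)nc3c2ncn3C)CC1` gives 631 nM. Among these three numbers compound 2 stands highest, with compound 3 the nearest and compound 1 the furthest, both gaps lying beyond the scatter of this assay.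

Compound 4 `CN1CCN(c2nc(-c3cccc(O)c3)nc3[nH]cnc23)CC1` has not yet been measured. Relative to compound 2, the change is 3-hydroxyphenyl in place of 2,5-dichlorophenyl on an aromatic carbon. Among the compounds with values here, no measured pair shows this exact change, so the expected step rests on the other two compounds. Because compound 3 gives 631 nM with a hydroxyphenyl group on its core, and compound 1 gives 126 nM with a single chlorine on its phenyl ring, a step toward a lower number is expected for compound 4, larger than the scatter. The step from compound 2 to compound 4 in this assay is estimated at a 5.6-fold lower number from compound 2 to compound 4 (0.75 log units; beyond the scatter). Compound 4 is therefore expected to give about 450 nM, with a range from 120 nM to 1600 nM.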

Compound 4, inhibition constant: 158 nM
The estimate for compound 4 lay 2.8-fold (0.45 log units) above the measured number, and the stated range covers the measured number.
By their numbers in this assay, from the lowest: compounds 1 and 4 (each within the scatter of the next); then compound 3; then compound 2.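

In this assay the exchange of 2,5-dichlorophenyl for 3-hydroxyphenyl gives a 16-fold lower number from compound 2 to compound 4 (1.20 log units; beyond the scatter), a large step and the first in this set that can be read at a single place. It shows that the group on this aromatic carbon, between two ring nitrogen atoms, can by itself shift the number far beyond the scatter while the 4-methylpiperazin-1-yl group and the rest of the molecule stay the same. No supporting evidence accounts for the size of this step.

The change removes two chlorines and adds a hydroxyl at once, so the compounds shown do not separate these two parts; an unsubstituted phenyl or a 3-methoxyphenyl group at this position would bear on that. Going by these compounds, it also remains open whether the step would hold if a morpholine replaced the 4-methylpiperazin-1-yl group.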